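The source may report more compounds than this note shows. Statements on the series, on what has been measured and on what is new or still open speak of the compounds shown alone.

Measured so far:
compound 1 `C=CCN1CCN(c2ccc(C(=O)Nc3n[nH]c4nc(-c5c(Cl)c(OC)cc(OC)c5Cl)ccc34)cc2)CC1` gives 3.3 nM
compound 2 `COc1cc(OC)c(Cl)c(-c2ccc3c(NC(=O)c4cnc(N5CCN(C)CC5)cn4)n[nH]c3n2)c1Cl` gives 60.6 nM

Both numbers come from a functional assay on NCI-H1581 cells (Homo sapiens) for antiproliferative activity, read by CCK-8 assay, with a stated time of 72 h (a higher number here means a weaker inhibitor, a lower number a stronger inhibitor), and compound 1 holds the lower one, with compound 2 higher by a gap beyond the scatter. Compound 3 `COc1cc(OC)c(Cl)c(-c2ccc3c(NC(=O)c4ccc(N)cc4)n[nH]c3n2)c1Cl` differs from compound 1 as follows: amino in place of 4-allylpiperazin-1-yl on an aromatic carbon with amino in place of 4-allylpiperazin-1-yl on an aromatic carbon. Among the compounds with values here, no measured pair shows this change alone. With compound 1 so low at 3.3 nM a step to a higher number, beyond the scatter, is expected in this assay here. The expected size is a 12-fold higher number from compound 1 to compound 3 (1.08 log units; beyond the scatter) on this thin basis. For compound 3 the estimated value is 40 nM with an expected range of 8 nM to 200 nM as a working figure.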

Compound 3, half-maximal inhibitory concentration: 218 nM
Compound 3: the middle estimate sits 5.5-fold (0.74 log units) below what was measured; the measured number lies above the stated range.
By their numbers in this assay, from the lowest: compound 1; then compound 2; then compound 3.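

In this assay, amino in place of 4-allylpiperazin-1-yl on an aromatic carbon, para to a large group, gives a 66-fold higher number from compound 1 to compound 3 (1.82 log units; beyond the scatter) on an otherwise unchanged structure. The number at this position therefore depends heavily on which group sits there, and a bare amino does not retain the low value of compound 1. No measurement available accounts for the size of this step.

The step removes the ring and the allyl together, so their shares cannot be separated. An unsubstituted piperazine, a 4-methylpiperazin-1-yl group or a morpholine at this position would test that.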